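The source may hold more compounds than are shown below. What is called first, only, known or untested is meant among the compounds shown, and "the series" means these compounds.

Measured compounds in a functional assay on the whole organism for inhibition, with Rattus norvegicus as the target, read by paw edema; a higher number here means that more compound is needed for the effect, a lower number that less compound is needed:
compound 1 `O=C(O)c1cc(-n2ccnc2)ccc1O`: 75 mg/kg
compound 2 `O=C(O)c1ccc(-c2ncco2)cc1O`: > 250 mg/kg
compound 3 `O=C(O)c1cc(-c2cncs2)ccc1O`: > 200 mg/kg

For the measured compounds named here, compound 1 holds the only numerical value among the three; in this assay compound 1 gives 75 mg/kg. For compound 2 the value > 250 mg/kg is a limit of the assay, not a number. For compound 3 the value > 200 mg/kg is likewise a limit. Going by the values given here, no step between compound 1 and compound 2 is given; their values show only that the number for compound 2 lies at a limit while compound 1 gives a number.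

Compound 4 `O=C(O)c1cc(-c2nccs2)ccc1O` has not yet been measured. It differs from compound 1 as follows: 1,3-thiazol-2-yl in place of 1H-imidazol-1-yl on an aromatic carbon.

Among the compounds with values here, the step that bears on this change is the one with compound 3, where another 1,3-thiazolyl replaces the imidazolyl: an at least 2.6-fold higher number from compound 1 to compound 3 (0.42 log units; beyond the scatter). That step ran to a limit (the limit of > 200 mg/kg in this assay, at which 1 of the 3 values shown sits), so its true size is not known, only that it is at least modest and beyond the scatter.

For compound 4 a higher number than for compound 1 is therefore expected, of a size comparable to a 2.4-fold higher number from compound 1 to compound 4 (0.38 log units; beyond the scatter), with a fair chance that this assay again reports only a limit. The estimate for compound 4 is 180 mg/kg, within 90 mg/kg to 400 mg/kg.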

Compound 4, dose for half-maximal effect: > 250 mg/kg
Compound 4: a limit, no number (the forecaster's own chance of this, stated with the estimate: 50%); middle value at least 1.3-fold (0.14 log units) from the limit.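

In this assay, 1,3-thiazol-2-yl in place of 1H-imidazol-1-yl, on the aromatic carbon para to the hydroxy group and meta to the carboxy group, gives an at least 3.3-fold higher number from compound 1 to compound 4 (0.52 log units; beyond the scatter). With this result, a second 1,3-thiazolyl attachment at this position joins the 1,3-thiazol-5-yl of compound 3 in moving away from compound 1, so the earlier loss is no longer tied to a single thiazolyl isomer, though the pattern rests on these two replacements alone. Compound 4 gives > 250 mg/kg, which is a limit and not a number: the limit of > 250 mg/kg in this assay, at which 2 of the 4 values shown sit.

The step between the two thiazolyl isomers cannot be read, so the compounds shown do not rank the 1,3-thiazol-2-yl and 1,3-thiazol-5-yl groups against each other, and the true size of each step away from compound 1 also remains unknown. Also open, from the compounds shown here alone, is whether any other group at this position, such as 1H-pyrazol-1-yl, a pyridinyl ring or a simple amine, would give a number close to that of compound 1 or would again reach a limit.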